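A larger alkyl group on the hydroxy-carbamoyl nitrogen

This account rests on a few compounds, and the source may have more. Where it says the series, first, only, none or still open, it means among the compounds named here.

Compound 1 `Cc1nc(-c2c(F)cc(Cl)cc2-c2cnc(CNC(=O)N(C)O)c(F)c2)no1` and compound 2 `CN(O)C(=O)NCc1ncc(-c2cc(Cl)cc(F)c2-c2nnn(C)n2)cc1F` share the same core bearing a (hydroxy(methyl)carbamoyl)amino side chain and differ only in the five-membered heteroaryl ring. In a functional assay on IMR-90 cells for antagonist activity at B1 bradykinin receptor (Homo sapiens), read by calcium flux (on this read-out higher numbers stand for weaker inhibition and lower numbers for stronger inhibition), compound 1 gives 17 nM, and compound 2 gives 17 nM; that step reads no change at the digits printed from compound 1 to compound 2 (within the scatter). Compound 2 therefore stands level with compound 1 within the scatter. Compound 3 `CC(C)N(O)C(=O)NCc1ncc(-c2cc(Cl)cc(F)c2-c2nnn(C)n2)cc1F` is derived from compound 2 by isopropyl in place of methyl on an amide-type nitrogen. Within the data shown here, no measured step touches this nitrogen: the one step in hand concerns the heteroaryl ring, a different part of the molecule, and lay within the scatter, so it offers no guide to the new change. In the absence of a precedent the expected step for compound 3 in this assay is a 1.5-fold higher number from compound 2 to compound 3 (0.17 log units; within the scatter), a slight weakening that may not exceed the scatter. Compound 3 is thus expected to give 25 nM, with a range from 8 nM to 80 nM.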

Compound 3, half-maximal inhibitory concentration: 1 nM
The estimate for compound 3 lay 25-fold (1.40 log units) above the measured number, outside the stated range (below it).
By their numbers in this assay, from the lowest: compound 3; then compounds 1 and 2 (each within the scatter of the next).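

Putting isopropyl in place of methyl on the amide-type nitrogen gives, in this assay, a 17-fold lower number from compound 2 to compound 3 (1.23 log units; beyond the scatter). This nitrogen is therefore a place where the read-out responds strongly, in contrast to the heteroaryl exchange, which gave no change at the digits printed from compound 1 to compound 2 (within the scatter), and the hydroxy(isopropyl)carbamoyl group goes with stronger inhibition than hydroxy(methyl)carbamoyl on this core. Nothing available accounts for the size of this step.

The compounds shown leave open whether inhibition strengthens further or falls away with a cyclopropyl group, a tert-butyl group or a longer chain such as n-butyl on this nitrogen. They also leave open whether the same change would carry over to the core of compound 1, which bears 5-methyl-1,2,4-oxadiazol-3-yl.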